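A few compounds are considered here, and "the series" means these few. Any claim that something is new, unique, unknown or untested is made for them only; others in the source may bear on it.

Measured compounds:
Compound 1 `COc1ccc(Nc2ncc(C(F)(F)F)c(N3Cc4cccc(N(C)S(C)(=O)=O)c4C3)n2)cc1C(F)(F)F`: 14000 nM
Compound 2 `Cc1cc(Cl)ccc1Nc1ncc(C(F)(F)F)c(N2Cc3cccc(N(C)S(C)(=O)=O)c3C2)n1`: 17400 nM

In a functional assay on HeLa cells (Homo sapiens) for antiproliferative activity, read by spectrophotometry, with a stated time of 2 days (a lower number here means a stronger inhibitor of growth, a higher number a weaker inhibitor of growth), compound 1 gives 14000 nM, the lower of the two numbers shown, while compound 2 gives 17400 nM. Among the compounds with values here, the one measured step, a 1.2-fold higher number from compound 1 to compound 2 (0.09 log units; within the scatter), exchanges the whole aryl group on the nitrogen and stays within the scatter. Compound 3 `CN(c1cccc2c1CN(c1nc(Nc3ccc(Cl)c(C(F)(F)F)c3)ncc1C(F)(F)F)C2)S(C)(=O)=O` differs from compound 1 by chloro in place of methoxy on an aromatic carbon. That step bears on the change only loosely, since it alters the same ring without testing this exchange alone, and its small size suggests no step beyond the scatter in this assay. Compound 3 is therefore expected to give 14000 nM (range 5000 nM to 40000 nM), a step of no change at the digits printed from compound 1 to compound 3 (within the scatter).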

Compound 3, concentration for 50% growth inhibition: 11100 nM
Beside the measured number, compound 3's estimate is 1.3-fold (0.10 log units) above it; measured number inside the range.
By their numbers in this assay, from the lowest: compounds 3, 1 and 2 (each within the scatter of the next).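

In this assay, within the data shown here, chloro in place of methoxy on the aromatic carbon ortho to the trifluoromethyl group gives a 1.3-fold lower number from compound 1 to compound 3 (0.10 log units; within the scatter) and so shows that this single exchange, which the earlier compounds did not isolate, produces no step beyond the scatter. Exchanging the whole aryl group gives a 1.6-fold lower number from compound 2 to compound 3 (0.20 log units; within the scatter) and also stays within the scatter. Nothing at hand speaks to the origin of these results.

As far as these compounds go, whether an amine, a carboxylic acid or a nitrile at this position would give a step beyond the scatter remains open. So does the outcome of replacing the trifluoromethyl group with a longer chain.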